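From 4-bromophenyl to 4-methylphenyl at one concentration

The source may report more compounds than this note shows. Statements on the series, on what has been measured and on what is new or still open speak of the compounds shown alone.

compound 1 `CN(C)C(=O)c1cc2cnc(Nc3ccc(NC(=O)C4(C(=O)Nc5ccc(F)cc5)CC4)cc3)nc2n1C1CCCC1`: 98%
compound 2 `CN(C)C(=O)c1cc2cnc(Nc3ccc(NC(=O)C4(C(=O)Nc5cccc(O)c5)CC4)cc3)nc2n1C1CCCC1`: 75.7%
compound 3 `CN(C)C(=O)c1cc2cnc(Nc3ccc(NC(=O)C4(C(=O)Nc5ccc(Br)cc5)CC4)cc3)nc2n1C1CCCC1`: 98.8%

In a functional assay on SiHa cells (Homo sapiens) for inhibition, read by CCK-8 assay, with a stated time of 72 h, tested at 10 uM (on this read-out lower numbers stand for less inhibition of growth and higher numbers for more inhibition of growth at the one concentration tested), compound 3 gives 98.8%, which lies within the scatter of compound 1 and well clear of compound 2. Compound 4 `Cc1ccc(NC(=O)C2(C(=O)Nc3ccc(Nc4ncc5cc(C(=O)N(C)C)n(C6CCCC6)c5n4)cc3)CC2)cc1` has methyl in place of bromo on an aromatic carbon, para to a large group: methyl in place of bromo on an aromatic carbon. Going by the values given here, no measured step makes this exact exchange. The closest is the exchange of fluoro for bromo, a number 0.8 percentage points higher from compound 1 to compound 3 (within the scatter), which stayed within the scatter. The larger steps, a number 22.3 percentage points lower from compound 1 to compound 2 (beyond the scatter) and a number 23.1 percentage points higher from compound 2 to compound 3 (beyond the scatter), both involve the 3-hydroxyphenyl group, which is absent here. In this assay the expected change, a number 4.8 percentage points lower from compound 3 to compound 4 (within the scatter), is therefore a small fall that stays within the scatter. For compound 4 the estimated value is 94%. The expected range for compound 4 runs from 80% to 100%.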

Compound 4, percent growth inhibition at one concentration: 104%
Compound 4: the middle estimate sits 10 percentage points below what was measured, and the stated range ends below it.
By their numbers in this assay, from the lowest: compound 2; then compounds 1, 3 and 4 (each within the scatter of the next).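

In this assay a methyl group on this aromatic carbon, para to a large group, reads like the two halogens, with a number 5.2 percentage points higher from compound 3 to compound 4 (within the scatter) and a number 6 percentage points higher from compound 1 to compound 4 (within the scatter) both inside the scatter, so the position is now seen to accept a carbon substituent as well as fluoro or bromo. Compound 2 remains apart, with a number 28.3 percentage points higher from compound 2 to compound 4 (beyond the scatter) as the third such gap from the 3-hydroxyphenyl compound. Nothing shown here accounts for these readings.

On these data alone, whether a methoxy, an amine or a carboxylic acid on this carbon would keep the reading stays open. A single concentration also leaves compounds 1, 3 and 4 unranked.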